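A few compounds are considered here, and "the series" means these few. Any claim that something is new, unique, unknown or untested is made for them only; others in the source may bear on it.

Compound 1 `CC1=CC[C@H](C(C)(C)NC(=S)N/N=C/c2ccc(O)cc2)CC1` stands at the edge of what a functional assay on 786-0 cells (Homo sapiens) for inhibition, read by sulforhodamine B assay, with a stated time of 48 h (on this read-out lower numbers stand for stronger inhibition of growth and higher numbers for weaker inhibition of growth), can resolve: in this assay compound 1 gives > 100000 nM, which is a limit rather than a number. Compound 2 `CC1=CC[C@H](C(C)(C)NC(=S)N/N=C/c2cccc([N+](=O)[O-])c2)CC1` likewise returns only a limit, as compound 2 gives > 100000 nM in this assay. For the measured compounds named here, both recorded values thus sit together at the limit of > 100000 nM in this assay, at which 2 of the 2 values shown sit, so no measured step can be drawn from them. Compound 3 `CC1=CC[C@H](C(C)(C)NC(=S)N/N=C/c2cccs2)CC1` arises from compound 1 by thiophen-2-yl in place of 4-hydroxyphenyl on a carbon with a double bond to nitrogen. With both measured compounds at the limit, the step is expected to stay within the usual scatter, estimated as a number no higher from compound 1 to compound 3 (the limit leaves the size open). Compound 3 is accordingly expected to give about 100000 nM, within 30000 nM to 300000 nM, and most probably to be reported again only as a limit.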

Compound 3, concentration for 50% growth inhibition: 11500 nM
Compound 3: middle estimate off by 8.7-fold (0.94 log units), on the high side; the measured number lies below the stated range.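

Compound 3 shows that this place, on a carbon with a double bond to nitrogen, can move the read-out: in this assay, thiophen-2-yl in place of 4-hydroxyphenyl gives an at least 8.6-fold lower number from compound 1 to compound 3 (0.93 log units; beyond the scatter). This size is only a minimum, and compound 3 alone among the three compounds has a number rather than a limit: the limit of > 100000 nM in this assay, at which 2 of the 3 values shown sit.

The compounds shown leave open whether the step depends on the ring sulfur or on the five-membered ring, which furan-2-yl could separate. From the compounds shown here alone, how an amine or a carboxylic acid on the thiophen-2-yl ring would read also remains open.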